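Ring-substituted piperidine analogue in the electroshock series

The compounds below may be only part of what the source reports. "The series", "measured", "known", "first", "only" and "open" are said of these compounds alone.

Measured so far:
compound 1 `CN(C)CCCOc1ccccc1/C=C/c1ccccc1` 14.2%
compound 2 `C(=C/c1ccccc1OCCCCN1CCCCC1)\c1ccccc1` 42.9%
compound 3 `CC(=O)N1CCN(CCCCOc2ccccc2/C=C/c2ccccc2)CC1` 0%

In a functional assay on the whole organism with Mus musculus as the target, in the maximal electroshock model, at a dose of 50 mg/kg by the oral route (a higher number here means more inhibition at the dose given (going by the name of the read-out), a lower number less inhibition), compound 2 gives 42.9%, the highest of the three numbers; the two steps around it are a number 28.7 percentage points higher from compound 1 to compound 2 (beyond the scatter) and a number 42.9 percentage points lower from compound 2 to compound 3 (beyond the scatter).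

Compound 4 `COC(=O)C1CCCN(CCCCOc2ccccc2/C=C/c2ccccc2)C1` differs from compound 2 by methoxycarbonyl in place of hydrogen on a saturated ring carbon. Going by the values given here, no measured step touches a ring carbon of the amine; both change the amine group itself. Among the compounds with values here, the only step that enlarges the amine ring, a number 42.9 percentage points lower from compound 2 to compound 3 (beyond the scatter), was a large fall, while the exchange of dimethylamino for piperidin-1-yl, a number 28.7 percentage points higher from compound 1 to compound 2 (beyond the scatter), was a modest rise. A fall is therefore expected, but the evidence is indirect and thin. Compound 4 is expected to give 20%, within 0% to 45%. That estimate means a step of a number 22.9 percentage points lower from compound 2 to compound 4 (beyond the scatter).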

Compound 4, a percentage reported as inhibition, in the whole organism at one dose (the size of the read-out at that dose, not a potency): 0%
Beside the measured number, compound 4's estimate is 20 percentage points above it, and the stated range covers the measured number.
By their numbers in this assay, from the lowest: compounds 3 and 4 (each within the scatter of the next); then compound 1; then compound 2.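

In this assay, a number 42.9 percentage points lower from compound 2 to compound 4 (beyond the scatter) follows from methoxycarbonyl in place of hydrogen on a saturated ring carbon, two ring bonds from the ring nitrogen. Going by these compounds alone, this is the first measured change on a ring carbon of the amine rather than to the amine group itself, and at this position the change removes the read-out seen for compound 2 at the dose given. Nothing available bears on the cause of this fall.

As far as these compounds go, whether a methyl group or a carboxylic acid on the same ring carbon would leave the number nearer that of compound 2 stays open. So does whether methoxycarbonyl on a different carbon of the ring gives the same fall.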